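A few compounds are considered here, and "the series" means these few. Any claim that something is new, unique, unknown or untested is made for them only; others in the source may bear on it.

In a functional assay on NPC-TW01 cells (Homo sapiens) for inhibition, read by MTT assay, with a stated time of 72 h (on this read-out lower numbers stand for stronger inhibition of growth and higher numbers for weaker inhibition of growth), three compounds built on the shared core have been measured. For the measured compounds named here, compound 1 `COC(=O)c1nc(C)n(-c2ccccc2C(F)(F)F)n1` gives > 100000 nM, which is a limit of the assay and not a number, the only one of the three values to sit at the limit of > 100000 nM in this assay, at which 1 of the 3 values shown sits. Compound 2 `COC(=O)c1nc(C)n(-c2ccc(F)cc2)n1` gives 15200 nM. Compound 3 `CCc1nc(C(=O)OC)nn1-c1ccc(F)cc1` gives 15800 nM, the higher of the two numbers reported, with compound 2 nearest; the step of a 1.0-fold higher number from compound 2 to compound 3 (0.02 log units; within the scatter) shows that the two lie within the scatter of each other.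

Compound 4 `CCCCc1nc(C(=O)OC)nn1-c1ccc(F)cc1` has not yet been measured. It differs from compound 3 by ethyl in place of hydrogen on a saturated chain carbon, two bonds along the chain from an aromatic carbon. Going by the values given here, the only measured step that bears on this change is a 1.0-fold higher number from compound 2 to compound 3 (0.02 log units; within the scatter), where methyl replaced hydrogen on the same chain without moving the number beyond the scatter. Growing that chain further is therefore expected to give a step of a 1.1-fold lower number from compound 3 to compound 4 (0.02 log units; within the scatter) that stays within the scatter. For compound 4 the estimate in this assay is 15000 nM, with a range from 6000 nM to 40000 nM.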

Compound 4, concentration for 50% growth inhibition: > 100000 nM
Compound 4: only a limit was reported; the forecaster's own chance of this, stated with the estimate: 10%; middle value at least 6.6-fold (0.82 log units) from the limit.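

Within this assay the length of this saturated chain is shown to matter: ethyl in place of hydrogen on a saturated chain carbon, two bonds along the chain from an aromatic carbon, gives an at least 6.3-fold higher number from compound 3 to compound 4 (0.80 log units; beyond the scatter) and so goes beyond the scatter, which the earlier methyl step did not. Extending the chain by propyl gives an at least 6.5-fold higher number from compound 2 to compound 4 (0.81 log units; beyond the scatter) as well, so among the chains at this position the butyl chain alone stands apart. The value of compound 4 is a limit and not a number, the same limit that compound 1 reaches: the limit of > 100000 nM in this assay, at which 2 of the 4 values shown sit.

The limit leaves the true size of both steps open. Also open, as far as these compounds go, is how a propyl chain, a longer chain, or an amine at the end of the chain would read at this position.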